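A Ring Swap With One Measured Step as Guide

The source may hold more compounds than are shown below. What is called first, only, known or untested is meant among the compounds shown, and "the series" means these compounds.

Compound 2 (`Cc1ccc(C)c(/C=C/[C@](C)(O)CC[C@@H]2[C@@]3(C)CCCC(C)(C)[C@@H]3CC[C@@]2(C)O)c1`) gives 3320 nM in a functional assay on A549 cells (Homo sapiens) for cytotoxicity, read by MTT assay, with a stated time of 48 h (on this read-out lower numbers stand for stronger inhibition and higher numbers for weaker inhibition), and compound 1 (`CC1(C)CCC[C@]2(C)[C@@H](CC[C@@](C)(O)/C=C/c3cccc([N+](=O)[O-])c3)[C@](C)(O)CC[C@@H]12`) gives 3400 nM there, so compound 2 stands level with compound 1, within the scatter. Compound 3 (`COc1cccc(OC)c1/C=C/[C@](C)(O)CC[C@@H]1[C@@]2(C)CCCC(C)(C)[C@@H]2CC[C@@]1(C)O`) keeps the shared core, and the change from compound 2 is 2,6-dimethoxyphenyl in place of 2,5-dimethylphenyl on a double-bonded chain carbon bound to a double-bonded chain carbon on a double-bonded chain carbon bound to a double-bonded chain carbon. For the measured compounds named here, only one measured step bears on this place: a 1.0-fold lower number from compound 1 to compound 2 (0.01 log units; within the scatter) with 2,5-dimethylphenyl in place of 3-nitrophenyl, and it lies within the scatter. Going by the values given here, no measured compound carries 2,6-dimethoxyphenyl, so the evidence is thin. No change beyond the scatter is therefore expected in this assay for this swap. The expected step is a 1.0-fold higher number from compound 2 to compound 3 (0.01 log units; within the scatter) and stays within the scatter. Compound 3 is estimated at 3400 nM (expected range 1500 nM to 7500 nM).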

Compound 3, half-maximal inhibitory concentration: 42000 nM
Compound 3: the middle estimate sits 12-fold (1.09 log units) below what was measured; the whole stated range lies below it.
By their numbers in this assay, from the lowest: compounds 2 and 1 (each within the scatter of the next); then compound 3.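

In this assay, 2,6-dimethoxyphenyl in place of 2,5-dimethylphenyl gives a 13-fold higher number from compound 2 to compound 3 (1.10 log units; beyond the scatter) and, in place of 3-nitrophenyl, gives a 12-fold higher number from compound 1 to compound 3 (1.09 log units; beyond the scatter) on the same chain carbon. The earlier pair showed only that 2,5-dimethylphenyl and 3-nitrophenyl stand level, whereas these steps show that the number at this place can change greatly with the ring it carries. Nothing available explains why this ring goes with the higher number.

The compounds shown leave open whether the two methoxy groups themselves or the places they hold on the ring go with the change. As far as these compounds go, it is also open whether a phenyl ring carrying an amine or a carboxylic acid would stand level with compound 2 or reach a number like that of compound 3.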